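The compounds below may be only part of what the source reports. "The series", "measured", "known", "first", "only" and "open" are said of these compounds alone.

Compound 1 `Cc1cc2c(cc1C(=O)N=C(N)N)S(=O)(=O)CC2(C)O`: 30 nM
Compound 2 `COC1(C)CS(=O)(=O)c2cc(C(=O)N=C(N)N)c(C)cc21`: 40 nM

Both numbers come from an assay on cells for inhibition of sodium/hydrogen exchanger (Oryctolagus cuniculus); a higher number here means a weaker inhibitor, a lower number a stronger inhibitor. Compound 1 gives the lowest of the two numbers, yet compound 2 lies within the scatter of it, the step being a 1.3-fold higher number from compound 1 to compound 2 (0.12 log units; within the scatter). Compound 3 `Cc1cc2c(cc1C(=O)N=C(N)N)S(=O)(=O)CC2O` differs from compound 1 by hydrogen in place of methyl on a saturated ring carbon. Among the measured compounds shown here, the only measured step concerns a methyl entering on the oxygen of the shared core, and it stayed within the scatter; no measured step removes a methyl from the saturated ring carbon. The expectation is therefore no change beyond the scatter, no change at the digits printed from compound 1 to compound 3 (within the scatter). Compound 3 is estimated at 30 nM, with a range from 12 nM to 80 nM.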

Compound 3, half-maximal inhibitory concentration: 70 nM
For compound 3 the middle estimate is 2.3-fold (0.37 log units) below the measured one; the measured number falls inside the stated range.
By their numbers in this assay, from the lowest: compounds 1, 2 and 3 (each within the scatter of the next, the first and the last beyond it).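

In this assay the methyl on the saturated ring carbon, two ring bonds from the ring sulfur, matters: hydrogen in its place gives a 2.3-fold higher number from compound 1 to compound 3 (0.37 log units; beyond the scatter) and so a modest loss of strength. This is the first step shown to pass beyond the scatter, whereas the methyl entering on the oxygen in a 1.3-fold higher number from compound 1 to compound 2 (0.12 log units; within the scatter) did not. Nothing available here explains the loss. The compounds shown leave open whether an ethyl group on that carbon would match the methyl, and how an amine or a fluorine atom there would compare.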